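A few compounds are considered here, and "the series" means these few. Any claim that something is new, unique, unknown or untested is made for them only; others in the source may bear on it.

Measured so far:
- compound 1 `O=C1/C(=C\c2ccccc2Cl)c2ccccc2N1c1c(Cl)cccc1Cl`: in a functional assay on KB cells (Homo sapiens) for cytotoxicity, read by MTT assay, with a stated time of 72 h (on this read-out higher numbers stand for an effect only at larger amounts of compound and lower numbers for an effect already at smaller amounts), compound 1 gives 5 ug/mL
- compound 2 `COc1ccc(/C=C2\C(=O)N(c3c(Cl)cccc3Cl)c3ccccc32)cc1`: for compound 2 the result is only a limit of the assay, > 100 ug/mL
- compound 3 `O=C1/C(=C\c2ccc(Cl)cc2)c2ccccc2N1c1c(Cl)cccc1Cl`: in this assay compound 3 gives 2 ug/mL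

Compound 3 has the lowest of the two numbers, with compound 1 nearest at a 2.5-fold lower number from compound 1 to compound 3 (0.40 log units; beyond the scatter). The unmeasured compound 4 `O=C1/C(=C\c2c(Cl)cccc2Cl)c2ccccc2N1c1c(Cl)cccc1Cl` differs from compound 3 by 2,6-dichlorophenyl in place of 4-chlorophenyl on a double-bonded chain carbon bound to a double-bonded ring carbon. Among the compounds with values here, the steps that bear on this are a 2.5-fold lower number from compound 1 to compound 3 (0.40 log units; beyond the scatter), which is modest, and the large ones an at least 20-fold higher number from compound 1 to compound 2 (1.30 log units; beyond the scatter) and an at least 50-fold lower number from compound 2 to compound 3 (1.69 log units; beyond the scatter), which concern methoxy rather than chlorine. Since moving a single chlorine from the 2-position to the 4-position changed the number only modestly, a modest step upward in this assay is expected for compound 4, a 3.0-fold higher number from compound 3 to compound 4 (0.48 log units; beyond the scatter). Compound 4 is estimated at 6 ug/mL, within 2 ug/mL to 20 ug/mL.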

Compound 4, concentration for half-maximal effect: 50 ug/mL
Beside the measured number, compound 4's estimate is 8.3-fold (0.92 log units) below it; measured number outside the range, above it.
By their numbers in this assay, from the lowest: compound 3; then compound 1; then compound 4. At a limit, above all of these: compound 2.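

In this assay, this position on the double-bonded chain carbon proves sensitive to how many chlorines the phenyl ring carries: 2,6-dichlorophenyl in place of 4-chlorophenyl on a double-bonded chain carbon bound to a double-bonded ring carbon gives a 25-fold higher number from compound 3 to compound 4 (1.40 log units; beyond the scatter), a large step. Adding one chloro in place of hydrogen on an aromatic carbon gives a 10-fold higher number from compound 1 to compound 4 (1.00 log units; beyond the scatter), a far larger shift than moving the single chlorine produced. Compound 2 stands at a limit: the limit of > 100 ug/mL in this assay, at which 1 of the 4 values shown sits.

Read against that limit, 2,6-dichlorophenyl in place of 4-methoxyphenyl gives an at least 2.0-fold lower number from compound 2 to compound 4 (0.30 log units; that floor lies within the scatter), which is a floor only.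

Why the second chlorine raises the number stays open. So does whether an amine or a carboxylic acid on this phenyl ring would keep the number low.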